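Sulfonamide benzophenones: a halogen swap on the sulfonyl ring

This account rests on a few compounds, and the source may have more. Where it says the series, first, only, none or still open, it means among the compounds named here.

Three benzophenone sulfonamides have been examined in an assay on CHO cells for binding affinity to integrin alpha-1 (Homo sapiens), read by WST assay, with a stated time of 2 h; on this read-out lower numbers stand for an effect already at smaller amounts and higher numbers for an effect only at larger amounts of compound. Compound 1 `O=C(c1ccccc1)c1ccc(NS(=O)(=O)c2ccc(Cl)cc2Cl)cc1` gives 20000 nM in this assay. Compound 2 `O=C(c1ccccc1)c1cccc(NS(=O)(=O)c2ccc(Cl)cc2Cl)c1` gives 17000 nM in this assay, and the gap between compound 1 and compound 2 lies within the usual scatter, so the two cannot be told apart on these numbers. Compound 3 `CN(c1ccc(C(=O)c2ccccc2)cc1)S(=O)(=O)c1ccc(Cl)cc1Cl` is reported as "not active" (no number reported) in this assay, with no number given. Compound 1 therefore sits alongside compound 2 as one of two weak but measurable actives, with compound 3 beneath the level that yields a figure.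

Compound 4 `O=C(c1ccccc1)c1ccc(NS(=O)(=O)c2ccc(I)cc2)cc1` differs from compound 1 in one place: 4-iodophenyl in place of 2,4-dichlorophenyl on a sulfonyl sulfur. Within the data shown here, no measured pair in this set shows what such a swap does in this assay, and nothing here points to a direction. The expectation is that the step from compound 1 to compound 4 stays within the scatter, and the estimated step of a 1.3-fold higher number from compound 1 to compound 4 (0.10 log units; within the scatter) reflects that. Compound 4 is expected to give about 25000 nM in this assay, in a range from 8000 nM to 80000 nM.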

Compound 4, half-maximal effective concentration: 22000 nM
For compound 4 the middle estimate is 1.1-fold (0.06 log units) above the measured one; the measured number falls inside the stated range.
By their numbers in this assay, from the lowest: compounds 2, 1 and 4 (each within the scatter of the next).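

Putting 4-iodophenyl in place of 2,4-dichlorophenyl on a sulfonyl sulfur gives a 1.1-fold higher number from compound 1 to compound 4 (0.04 log units; within the scatter) in this assay and is the only step between measured compounds shown here. It shows that, at this position, a measurable number in this assay does not depend on keeping both chlorine atoms, since compound 4 carries a single iodine and still returns a figure, and the two groups cannot be told apart. No measurement at hand offers an explanation for this result.

Going by these compounds, what remains open is whether a different kind of group on the sulfonyl sulfur, such as a phenyl ring bearing an amine or a carboxylic acid, would shift the number beyond the scatter. The compounds shown also leave open whether a phenyl ring without any halogen would still give a figure.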